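The source may report more compounds than this note shows. Statements on the series, on what has been measured and on what is new or still open speak of the compounds shown alone.

Measured compounds:
compound 1, `CC(C)CC/N=C(\NC#N)Nc1cc(C(F)(F)F)cc(C(F)(F)F)c1`, giving 5600 nM in a functional assay (aorta) with Rattus norvegicus as the target; on this read-out higher numbers stand for weaker inhibition and lower numbers for stronger inhibition
compound 2, `CC(C)/N=C(\NC#N)Nc1cc(C(F)(F)F)cc(C(F)(F)F)c1`, giving 61000 nM in this assay
compound 3, `CC(C)CC/N=C(\NC#N)Nc1cc(Cl)cc(Cl)c1`, giving 18700 nM in this assay

Compound 1 and compound 2 share one core and differ only in one place: isopropyl in place of isopentyl on a double-bonded nitrogen. In this assay this change made an 11-fold higher number from compound 1 to compound 2 (1.04 log units; beyond the scatter). Compound 3 carries a different core; how it differs from the core of compound 1 is not broken down here. Its number in this assay lies lower than that of compound 2 and higher than that of compound 1.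

Compound 4, `CC(C)/N=C(\NC#N)Nc1cc(Cl)cc(Cl)c1`, is not yet measured. It differs from compound 3 by isopropyl in place of isopentyl on a double-bonded nitrogen. The change and its place are the same, word for word, as for compound 1 to compound 2, so the same change is made on the core of compound 3. Going by the values given here, only one measured example of this change exists, so the expectation rests on a single step: from compound 3 to compound 4 a step of about a 9.6-fold higher number from compound 3 to compound 4 (0.98 log units; beyond the scatter) is expected in this assay, because the same change gave an 11-fold higher number from compound 1 to compound 2 (1.04 log units; beyond the scatter). For compound 4 the expected value is therefore 180000 nM, estimated to fall between 50000 nM and 600000 nM.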

Compound 4, half-maximal inhibitory concentration: 52000 nM
Compound 4: the middle estimate sits 3.5-fold (0.54 log units) above what was measured, and the stated range covers the measured number.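

On the core of compound 3, isopropyl in place of isopentyl on a double-bonded nitrogen gave a 2.8-fold higher number from compound 3 to compound 4 (0.44 log units; beyond the scatter) in this assay, the same direction as on the core of compound 1. The direction of the change carries over between these two cores, but its size does not: the same change on two cores in this assay, an 11-fold higher number (1.04 log units; beyond the scatter) from compound 1 to compound 2 and a 2.8-fold higher number (0.44 log units; beyond the scatter) from compound 3 to compound 4, 3.9-fold (0.59 log units) apart, beyond the scatter of two such steps
Going by these compounds alone, with only two cores, this pair of steps does not show why the size differs, nor where a step on a further core would fall.

The compounds shown carry only isopentyl and isopropyl on the double-bonded nitrogen, which leaves open how a longer chain, a cyclohexyl group or a chain ending in an amine would read on either core. Also open, as far as these compounds go, is how large the step would be on a core carrying one chlorine and one trifluoromethyl group.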